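Series notes: naphthyridine-carboxamide variants in the MCF7 cytotoxicity read-out

The compounds below may be only part of what the source reports. "The series", "measured", "known", "first", "only" and "open" are said of these compounds alone.

Four compounds share one core. Compound 1 `N[C@H]1CC[C@H](Nc2c(C(=O)NCc3ccc(F)cc3)nc(N3CCCCS3(=O)=O)c3cccnc23)CC1` carries a cyclic sulfonamide on the aromatic ring and a diaminocyclohexyl amine; in a functional assay on MCF7 cells (Homo sapiens) for cytotoxicity, read by MTT assay, with a stated time of 72 h (on this read-out higher numbers stand for weaker inhibition and lower numbers for stronger inhibition), compound 1 gives 13000 nM, a weak result. Compound 2 `O=C(NCc1ccc(F)cc1)c1nc(Br)c2cccnc2c1NCc1ccc(F)cc1` replaces that sulfonamide with bromine and carries a 4-fluorobenzyl amine and a 4-fluorobenzyl amide. Compound 3 `N[C@H]1CC[C@H](NC(=O)c2nc(Br)c3cccnc3c2NCc2ccc(F)cc2)CC1` keeps the bromine and the 4-fluorobenzyl amine but returns to the diaminocyclohexyl amide. Neither compound 2 nor compound 3 has a number in this assay. In this assay compound 2 is reported as "not determined" (no result reported). In this assay compound 3 is likewise reported as "not determined" (no result reported). So compound 2 stands nowhere on the numbers, and there is one further compound without a number beside it.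

The step to compound 4 `CNCCCNc1c(C(=O)NCc2ccc(F)cc2)nc(Br)c2cccnc12` changes compound 2 at one place: 2-(methylamino)ethyl in place of 4-fluorophenyl on a saturated chain carbon bound to a nitrogen on an aromatic ring

Among the measured compounds shown here, no measured pair differs at a single place, so no measured step gives a scale for this change. For the measured compounds named here, without a number for compound 2, the direction of the step cannot be anchored; the only number in this assay is that of compound 1, which is weak. For compound 4 the expectation is a similarly weak result, estimated at 15000 nM with a range from 3000 nM to 60000 nM, and a fair chance that only a limit is reported.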

Compound 4, half-maximal inhibitory concentration: > 10000 nM
Compound 4: a limit, no number (the forecaster's own chance of this, stated with the estimate: 30%); the middle value is on the limit's open side.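

In this assay compound 4 gives > 10000 nM, which is a limit and not a number. Among the compounds shown here, with no single number for compound 2 either, no step from compound 2 to compound 4 can be read. The compounds shown leave open what the change from 4-fluorobenzyl to 3-(methylamino)propyl does in this read-out.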